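Swapping the benzyl arm for a phenoxy arm

The source may hold more compounds than are shown below. What is called first, only, known or untested is meant among the compounds shown, and "the series" means these compounds.

Measured so far:
- compound 1, `Cc1cccc(Cc2nc3cc(O[C@H]4CC[C@@H](C(=O)O)CC4)ccc3o2)c1`: in an assay on isolated protein for inhibition of Long-chain-fatty-acid--CoA ligase 1 (Homo sapiens), read by mass spectrometry, with a stated time of 90 min, in the presence of a further agent that is not named here (on this read-out lower numbers stand for stronger inhibition and higher numbers for weaker inhibition), compound 1 gives 39 nM.
- compound 2, `Cc1cccc(Cc2nc3ccc(O[C@H]4CC[C@@H](C(=O)O)CC4)cc3n2C)c1`: in this assay compound 2 gives only a limit, > 200000 nM.
- compound 3, `Cc1ccc(Cc2nc3cc(O[C@H]4CC[C@@H](C(=O)O)CC4)ccc3n2C)cc1`: in this assay compound 3 gives 150 nM.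

Only two of the three results are actual numbers, and compound 3 holds the higher of the two, meaning the weaker inhibition. Compound 1 sits below it by a gap that is beyond the usual scatter of repeated measurements, so the difference between these two is real. Compound 2 contributes a limit rather than a number and cannot be ranked against either.

The next compound, compound 4, `Cc1cccc(Oc2nc3cc(O[C@H]4CC[C@@H](C(=O)O)CC4)ccc3n2C)c1`, is built from compound 3 by one change: 3-methylphenoxy in place of 4-methylbenzyl on an aromatic carbon. The ring that leaves and the ring that enters are the same size, but the link to the shared core switches from a carbon to an oxygen, and the methyl moves around the ring. Among the measured compounds shown here, no measured pair isolates this kind of change, so there is no step to lean on. The expectation is therefore a modest shift, most likely toward a somewhat higher number, with wide uncertainty in both directions: compound 4 is estimated at 220 nM, within 40 nM to 1500 nM, which would correspond to a 1.5-fold higher number from compound 3 to compound 4 (0.17 log units; within the scatter).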

Compound 4, half-maximal inhibitory concentration: 78000 nM
For compound 4 the middle estimate is 350-fold (2.55 log units) below the measured one, outside the stated range (above it).
By their numbers in this assay, from the lowest: compound 1; then compound 3; then compound 4. At a limit, above all of these: compound 2.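

The arm on the aromatic carbon between two ring nitrogen atoms turns out to be far from interchangeable: in this assay the change gives a 520-fold higher number from compound 3 to compound 4 (2.72 log units; beyond the scatter) even though the ring and the count of heavy atoms in the arm stay the same. The earlier compounds shown here gave no view of this, as no measured pair varied the arm alone, and this step shows that a swap leaving the size of the arm untouched can still remove nearly all of the inhibition. Compound 4 still reads as a real number and not as a limit, so the size of the step can be stated, and the ceiling of the read-out lies here: the limit of > 200000 nM in this assay, at which 1 of the 4 values shown sits.

The step changes two things at once, the link to the core going from carbon to oxygen and the methyl taking a new place on the ring, so the compounds shown cannot say which of the two carries the loss. A 4-methylphenoxy arm would separate them, and an arm joined through an amine nitrogen would show whether the drop is tied to oxygen itself or to any link other than carbon.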